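The source may hold more compounds than are shown below. What is called first, only, known or untested is meant among the compounds shown, and "the series" means these compounds.

Three compounds with one shared core, differing only in the aromatic group on an amide-type nitrogen, have been measured in a functional assay on T47D cells (Homo sapiens) for inhibition, read by CCK-8 assay, with a stated time of 72 h, tested at 1 uM; a lower number here means less inhibition of growth, a higher number more inhibition of growth at the concentration tested. Compound 1 `CN(C)C(=O)c1cc2cnc(Nc3ccc(NC(=O)C4(C(=O)Nc5ccc(Cl)cc5)CC4)cc3)nc2n1C1CCCC1` gives 22.8%, compound 2 `CN(C)C(=O)c1cc2cnc(Nc3ccc(NC(=O)C4(C(=O)Nc5cccc(O)c5)CC4)cc3)nc2n1C1CCCC1` gives 80.7%, and compound 3 `COc1cccc(NC(=O)C2(C(=O)Nc3ccc(Nc4ncc5cc(C(=O)N(C)C)n(C6CCCC6)c5n4)cc3)CC2)c1` gives 56.3%. Compound 3 is thus the second highest of the three, with a number 24.4 percentage points lower from compound 2 to compound 3 (beyond the scatter) on one side and a number 33.5 percentage points higher from compound 1 to compound 3 (beyond the scatter) on the other.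

The next compound is compound 4 `CN(C)C(=O)c1cc2cnc(Nc3ccc(NC(=O)C4(C(=O)Nc5ccc(C(F)(F)F)cc5)CC4)cc3)nc2n1C1CCCC1`, and the change from compound 3 is 4-(trifluoromethyl)phenyl in place of 3-methoxyphenyl on an amide-type nitrogen. In short, 4-(trifluoromethyl)phenyl stands in place of 3-methoxyphenyl on an amide-type nitrogen.

The most useful precedent is a number 33.5 percentage points higher from compound 1 to compound 3 (beyond the scatter), a large step in which 3-methoxyphenyl replaced 4-chlorophenyl. Within the data shown here, compound 4 moves roughly the opposite way, since its new group, like the one in compound 1, carries no oxygen. The large step of a number 57.9 percentage points higher from compound 1 to compound 2 (beyond the scatter) fits the same picture, as both oxygen-bearing compounds read higher than compound 1. Still, three compounds are a thin basis, and none of them carries a trifluoromethyl group.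

A large downward change is therefore expected, with the estimated step being a number 29.3 percentage points lower from compound 3 to compound 4 (beyond the scatter). The estimated value for compound 4 is 27%, with an expected range from 10% to 48%.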

Compound 4, percent growth inhibition at one concentration: 29.6%
Compound 4: middle estimate off by 2.6 percentage points, on the low side, and the stated range covers the measured number.
By their numbers in this assay, from the lowest: compounds 1 and 4 (each within the scatter of the next); then compound 3; then compound 2.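

Trifluoromethyl in place of chloro on an aromatic carbon gives a number 6.8 percentage points higher from compound 1 to compound 4 (within the scatter) in this assay, so at this position the two groups cannot be told apart. Compound 4 gives the low reading of compound 1 a second example: 4-(trifluoromethyl)phenyl in place of 3-methoxyphenyl gives a number 26.7 percentage points lower from compound 3 to compound 4 (beyond the scatter) and in place of 3-hydroxyphenyl gives a number 51.1 percentage points lower from compound 2 to compound 4 (beyond the scatter), so across these four compounds the two groups carrying oxygen read above the two without it, and none of the four goes against this. No measurement at hand explains this difference.

As far as these compounds go, both oxygen-bearing groups also differ from the other two in the number in the group's name, so it remains open whether the oxygen or the ring position goes with the higher readings, a question that 4-hydroxyphenyl or 3-(trifluoromethyl)phenyl on the same amide-type nitrogen could help settle. From the compounds shown here alone, it is also open whether a 3-aminophenyl or 3-carboxyphenyl group would read like 3-hydroxyphenyl, and whether these differences hold at other concentrations.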